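Chain-position of the hydroxyl in two chloro-aryl ethers

The compounds below may be only part of what the source reports. "The series", "measured", "known", "first", "only" and "open" are said of these compounds alone.

Three compounds carry a chlorine-bearing aromatic ring joined through an oxygen to a short hydroxylated chain. Compound 1 is `CC(O)COc1ccc(Cl)cc1`; in a physicochemical assay for lipophilicity, measured as octanol-water partition (on this read-out lower numbers stand for lower lipophilicity and higher numbers for higher lipophilicity), compound 1 gives 2.16, the lowest of the three numbers. Compound 2 is `Cc1cccc(Cl)c1OCC(C)O` and in this assay compound 2 gives 2.73. Compound 3 is `Cc1cccc(Cl)c1OCCCO` and in this assay compound 3 gives 2.93. The difference between the core of compound 1 and the core of compound 2 is not broken down here; their values show compound 2 higher by a margin beyond the scatter.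

Compounds 2 and 3 differ by a single change, (2-hydroxyethyl in place of 1-hydroxyethyl on a saturated chain carbon bound to an oxygen on an aromatic ring), and this change gives a number 0.20 log units higher from compound 2 to compound 3 (within the scatter), a step that sits within the scatter.

Compound 4, `OCCCOc1ccc(Cl)cc1`, is not yet measured. It stands to compound 1 as compound 3 stands to compound 2: the difference is 2-hydroxyethyl in place of 1-hydroxyethyl on a saturated chain carbon bound to an oxygen on an aromatic ring, the same change at the same place. Among the compounds here the change occurs twice, once measured and once pending.

For the measured compounds named here, the expectation for compound 4 rests on the one measured instance of the change. The step from compound 1 to compound 4 is estimated as a number 0.20 log units higher from compound 1 to compound 4 (within the scatter), carried over from a number 0.20 log units higher from compound 2 to compound 3 (within the scatter). On that basis, compound 4 is expected to give 2.36 in this assay, with the likely range estimated as 2.1 to 2.65. The measured result is awaited.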

Compound 4, partition coefficient: 2.36
Compound 4: the middle estimate sits on the measured number at the digits printed; the measured number falls inside the stated range.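

On the core of compound 1, 3-hydroxypropyl in place of 2-hydroxypropyl gives a number 0.20 log units higher from compound 1 to compound 4 (within the scatter) in this assay, and the same change on the other core gives a number 0.20 log units higher from compound 2 to compound 3 (within the scatter), so the two steps agree in size at the digits printed and the carry-over from one core to the other holds for these two pairs. It does not show that the change itself moves this read-out: each step lies within the scatter, so the agreement of two such small steps cannot separate a real shared shift from repeat-to-repeat variation, and two cores make no general rule for the series. No information bearing on why the steps agree is available for these compounds.

The compounds shown cover only two cores and one read-out, so whether the same step would appear on a third core, or in any other kind of assay, stays open. Also open, going by these compounds, is how a step on this chain would read with an amine or a carboxylic acid in place of the hydroxyl, or with a longer chain such as 4-hydroxybutyl, where a step beyond the scatter might or might not appear.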